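The source may hold more compounds than are shown below. What is called first, only, known or untested is meant among the compounds shown, and "the series" means these compounds.

Three compounds in this series share a common core and differ in the groups attached to it. Compound 1 `Cc1cccc(N2CCN(CCCNc3nc(NCc4ccco4)c4ccccc4n3)CC2)c1C` and compound 3 `CCCCCNc1nc(NCc2ccco2)c2cc(F)ccc2n1` were tested in a functional assay on HCT-116 cells (Homo sapiens) for cytotoxicity, read by MTT assay, with a stated time of 2 days, tested at 10 uM (on this read-out lower numbers stand for less inhibition and higher numbers for more inhibition at the one concentration tested (going by the name of the read-out)), while compound 2 `CN(C)CCNc1nc(NCc2ccco2)c2ccccc2n1` carries no result in this assay, its entry reading "not determined" (no result reported). In this assay compound 1 gives 93.2%, and compound 3 gives 94.2%. Among the two numbers available, compound 1 has the lower one, but its gap to compound 3 lies within the usual scatter of this kind of measurement, so the two compounds cannot be told apart on these figures.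

Compound 4 `Cc1cccc(N2CCN(CCCNc3nc(NCc4ccco4)c4cc(F)ccc4n3)CC2)c1C` has not yet been measured. Compared with compound 1, the only change is fluoro in place of hydrogen on an aromatic carbon. For the measured compounds named here, no single-change step between two measured compounds is available to show what such a swap does here. With both measured values sitting close together, compound 4 is expected to stay within the scatter of compound 1, the expected step from compound 1 to compound 4 in this assay being a number 0.2 percentage points lower from compound 1 to compound 4 (within the scatter). Compound 4 is therefore estimated to give 93%, with a plausible range from 85% to 98%.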

Compound 4, a percentage reported as inhibition, at one concentration (the size of the read-out at that concentration, not a potency): 97.3%
Beside the measured number, compound 4's estimate is 4.3 percentage points below it; low and high end bracket the measured number.
By their numbers in this assay, from the lowest: compounds 1, 3 and 4 (each within the scatter of the next).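

For the compounds shown here, this is the first pair that differ in one place only, so the effect of this swap can now be read directly. In this assay fluoro in place of hydrogen on an aromatic carbon of the shared core gives a step of a number 4.1 percentage points higher from compound 1 to compound 4 (within the scatter) and therefore, at this position, the change cannot be told apart from no change, so the added fluorine leaves the read-out effectively intact. No measurement shown here explains this outcome.

On these data alone, whether a larger or different group at this position, such as chloro, methoxy or an amine, would leave the read-out equally unchanged remains open. A single tested concentration also leaves open whether compound 1 and compound 4 would separate in a full potency measurement across several concentrations.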